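Shortening the Chain on the Ring Nitrogen

The source may hold more compounds than are shown below. What is called first, only, known or untested is meant among the compounds shown, and "the series" means these compounds.

Compound 1 `CCCCCn1ccc2cc(/C(C)=C/C(=O)Nc3ccccc3OCCCC(=O)O)ccc21`: 23 nM in an assay on Prostate gland for inhibition of steroid 5-alpha-reductase (Rattus norvegicus); a lower number here means a stronger inhibitor, a higher number a weaker inhibitor
Compound 2 `CC(C)=CCn1ccc2cc(/C(C)=C/C(=O)Nc3ccccc3OCCCC(=O)O)ccc21`: 120 nM in this assay

Of the two measured compounds, compound 1 has the lower number in this assay, and compound 2 stands above it by a 5.2-fold higher number from compound 1 to compound 2 (0.72 log units; beyond the scatter). Compound 3 `CCC(C)n1ccc2cc(/C(C)=C/C(=O)Nc3ccccc3OCCCC(=O)O)ccc21` differs from compound 1 in the same chain that was altered in that step: sec-butyl in place of pentyl on an aromatic nitrogen. Going by the values given here, the one measured step that bears on this place, a 5.2-fold higher number from compound 1 to compound 2 (0.72 log units; beyond the scatter), shows that swapping the chain on the aromatic nitrogen can move the number by a modest amount, upward. A shorter, branched chain is a different change from that one, so its size is uncertain, but a modest rise beyond the scatter seems the most likely outcome. Compound 3 is therefore expected to show a 2.6-fold higher number from compound 1 to compound 3 (0.42 log units; beyond the scatter), landing at an estimated 60 nM with a range from 20 nM to 180 nM.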

Compound 3, half-maximal inhibitory concentration: 67 nM
The estimate for compound 3 lay 1.1-fold (0.05 log units) below the measured number; low and high end bracket the measured number.
By their numbers in this assay, from the lowest: compound 1; then compounds 3 and 2 (each within the scatter of the next).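

Replacing pentyl with a different kind of chain on the aromatic nitrogen again weakens inhibition in this assay (a 2.9-fold higher number from compound 1 to compound 3 (0.46 log units; beyond the scatter)), so the earlier rise is not unique to 3-methylbut-2-en-1-yl. The sec-butyl and 3-methylbut-2-en-1-yl chains cannot be ranked against each other (a 1.8-fold lower number from compound 2 to compound 3 (0.25 log units; within the scatter)), which leaves pentyl as the only chain of these three that stands apart, with the lowest number. Nothing available here explains why pentyl differs from the other two chains.

Sec-butyl is both shorter than pentyl and branched, so a straight butyl chain would be needed to separate the effect of length from that of branching. As far as these compounds go, whether a longer chain such as hexyl would lower the number further, or raise it again, remains open.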